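Ester variation on the shared core: cytotoxicity notes

A few compounds are considered here, and "the series" means these few. Any claim that something is new, unique, unknown or untested is made for them only; others in the source may bear on it.

Measured so far:
compound 1 `CC(=O)OC1CC2(N(C)C)CC(c3ccccc3)C1C(c1ccccc1)C2`: "not determined" (no result reported) in an ADME assay on L6 cells (Rattus norvegicus) for cytotoxicity, with a stated time of 72 h; a lower number here means a stronger inhibitor, a higher number a weaker inhibitor
compound 2 `CC(C)(C)C(=O)OC1CC2(N3CCCCC3)CC(c3ccccc3)C1C(c1ccccc1)C2`: 12000 nM

Compound 1 stands without a number in this assay, so its position cannot be placed; the only anchor in the series is compound 2, which gives 12000 nM. Compound 3 `CN(C)C12CC(OC(=O)/C=C/c3ccccc3)C(C(c3ccccc3)C1)C(c1ccccc1)C2` differs from compound 1 in one place: 2-phenylethenyl in place of methyl on a carbonyl carbon. With compound 1 unmeasured, the step from compound 1 to compound 3 in this assay cannot be sized or given a direction; nothing beyond the scatter is claimed. The expectation for compound 3 rests on the weak cytotoxicity seen for compound 2 at 12000 nM. Compound 3 is expected near 10000 nM, with a range from 2500 nM to 40000 nM.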

Compound 3, half-maximal inhibitory concentration: 3820 nM
Estimate against measurement, compound 3: 2.6-fold (0.42 log units) above; the range from low to high includes it.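

No new step can be read for compound 3: its one-place partner, compound 1, has no number in this assay. The compounds shown leave open how 2-phenylethenyl compares with methyl on this carbonyl carbon. Nothing at hand explains the result.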